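The source may report more compounds than this note shows. Statements on the series, on what has been measured and on what is new or still open speak of the compounds shown alone.

Measured compounds:
Compound 1 `COc1ccc(-n2ccnc2SCC(=O)Nc2ccccc2C)cc1`: in an ADME assay on MT4 cells (Homo sapiens) for cytotoxicity, read by MTT assay (a higher number here means that more compound is tolerated, a lower number that less compound is tolerated), compound 1 gives > 353000 nM, a limit of the assay.
Compound 2 `COc1ccc(-n2ccnc2SCC(=O)Nc2ccccc2Br)cc1`: in this assay compound 2 gives > 298000 nM, also a limit.
Compound 3 `Cc1ccc(-n2ccnc2SCC(=O)Nc2ccccc2Br)cc1`: in this assay compound 3 gives 39300 nM.

Compound 2 thus stands at a limit, and one further value shown is a limit as well. The step at the same position, a step that the two limits leave unreadable from compound 1 to compound 2, sits between the limit of > 353000 nM in this assay, at which 1 of the 3 values shown sits, and (the limit of > 298000 nM in this assay, at which 1 of the 3 values shown sits). The other step, an at least 7.5-fold lower number from compound 2 to compound 3 (0.87 log units; beyond the scatter), changes a different place. Compound 4 `COc1ccc(-n2ccnc2SCC(=O)Nc2ccccc2[N+](=O)[O-])cc1` differs from compound 2 by nitro in place of bromo on an aromatic carbon. No readable step covers this change, so no step beyond the scatter is expected in this assay, with a broad range. Compound 4 is estimated at 250000 nM, between 60000 nM and 400000 nM, meaning an expected at least 1.1-fold lower number from compound 2 to compound 4 (0.07 log units; that floor lies within the scatter).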

Compound 4, half-maximal cytotoxic concentration: 161000 nM
Estimate against measurement, compound 4: 1.6-fold (0.19 log units) above; the measured number falls inside the stated range.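

Nitro is the first group at this place, with methoxy kept on the other ring, to give a number rather than a limit in this assay. The change from methyl to nitro gives an at least 2.1-fold lower number from compound 1 to compound 4 (0.34 log units; beyond the scatter), whereas the change from bromo to nitro gives an at least 1.8-fold lower number from compound 2 to compound 4 (0.26 log units; that floor lies within the scatter). The second step stays a floor because compound 2 stands at a limit: the limit of > 298000 nM in this assay, at which 1 of the 4 values shown sits.

As far as these compounds go, whether an amine or a carboxylic acid at this place would also give a number remains open. So does whether methyl in place of methoxy lowers the number with nitro as it does with bromo.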